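A few compounds are considered here, and "the series" means these few. Any claim that something is new, unique, unknown or untested is made for them only; others in the source may bear on it.

Among the compounds with values here, in a functional assay on ZR-75-1 cells (Homo sapiens) for cytotoxicity, read by MTT assay, with a stated time of 72 h (a higher number here means that more compound is needed for the effect, a lower number that less compound is needed), compound 1 (`CCOC(=O)c1c(C)coc1-c1ccc2c(CC)cccc2c1OC`) gives 3.9 ug/mL as the only exact number so far. Compound 2 (`CCc1cccc2c(OC(C)=O)c(-c3occ(C)c3COC(C)=O)ccc12`) is reported as > 10 ug/mL and this is a limit of the assay, not a number. Within the data shown here, compound 1 is therefore the single firm reference point, and no measured pair of compounds yet shows how far one structural change can move the result. Compound 3 (`CCOCc1c(C)coc1-c1ccc2c(CC)cccc2c1OC`) keeps the core of compound 1 and alters one group (ethoxymethyl in place of ethoxycarbonyl on an aromatic carbon). Ethoxymethyl stands in place of ethoxycarbonyl on an aromatic carbon of the five-membered aromatic ring with 1 oxygen, next to the ring atom that bears a methyl group. Among the measured compounds shown here, with only this one group altered and no measured step to serve as a guide, the expected outcome in this assay is a result close to that of compound 1, perhaps leaning slightly toward more compound being needed. The estimated step of a 1.3-fold higher number from compound 1 to compound 3 (0.11 log units; within the scatter) is expected to stay within the usual scatter. For compound 3 the estimated value is 5 ug/mL with an expected range of 2 ug/mL to 10 ug/mL in this measurement.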

Compound 3, concentration for half-maximal effect: 9.1 ug/mL
Beside the measured number, compound 3's estimate is 1.8-fold (0.26 log units) below it, within the range that was stated.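

In this assay, within the data shown here, putting ethoxymethyl in place of ethoxycarbonyl on this aromatic carbon gives a 2.3-fold higher number from compound 1 to compound 3 (0.37 log units; beyond the scatter), the first measured step here, so what this position carries does affect the result. The swap is small, with ethoxymethyl having 4 heavy atoms and 1 hydrogen-bond acceptor against 5 heavy atoms and 2 hydrogen-bond acceptors for ethoxycarbonyl, and neither group has a ring or a net charge, yet more compound is needed for the effect. Nothing shown here measures a property that would explain this step, so the numbers record the change without giving its cause.

A single step cannot separate the loss of the carbonyl from any other difference between the two groups, and the compounds shown leave open how a carboxylic acid, an amide or a longer chain on this same carbon would compare with compound 1. They also leave open whether this step would stay the same size if another part of the shared core were changed as well.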